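Swapping a carbamate for a urea: cytotoxicity outlook

The source may hold more compounds than are shown below. What is called first, only, known or untested is meant among the compounds shown, and "the series" means these compounds.

Compound 1 `CCN(CC)c1cc2[nH]c(C3CCCCC3)nc2cc1NC(=O)c1cnccn1` and compound 2 `CCCC(C)OC(=O)Nc1cc2nc(C3CCCCC3)[nH]c2cc1N(CC)CC` share one core and differ only at a carbonyl carbon. In an ADME assay on Vero cells (Chlorocebus sabaeus) for cytotoxicity, read by resazurin assay, with a stated time of 3 days (on this read-out lower numbers stand for stronger inhibition and higher numbers for weaker inhibition), compound 1 gives > 100 ug/mL, which is a limit of the assay rather than a number. Compound 2 likewise gives > 100 ug/mL, again a limit. The step that the two limits leave unreadable from compound 1 to compound 2 cannot be read, since (the limit of > 100 ug/mL in this assay, at which 2 of the 2 values shown sit). Compound 3 `CCCNC(=O)Nc1cc2nc(C3CCCCC3)[nH]c2cc1N(CC)CC` differs from compound 2 by propylamino in place of 1-methylbutoxy on a carbonyl carbon. With no readable step to guide it, compound 3 is expected to sit at the same limit, and a step that the limit leaves unreadable from compound 2 to compound 3 is expected to stay within the scatter. The estimate for compound 3 is 150 ug/mL, between 60 ug/mL and 400 ug/mL.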

Compound 3, half-maximal inhibitory concentration: > 100 ug/mL
Compound 3: a limit, no number; the forecaster's own chance of this, stated with the estimate: 80%; the middle value does not contradict the limit.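

Compound 3 also gives only a limit, so no step among compound 1, compound 2 and compound 3 can be read: the limit of > 100 ug/mL in this assay, at which 3 of the 3 values shown sit.

Whether pyrazin-2-yl, 1-methylbutoxy and propylamino on the carbonyl carbon differ at all in this assay stays open, since none of these compounds gives a number.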